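Trading trifluoromethyl for methyl on compound 3

The source may hold more compounds than are shown below. What is called first, only, known or untested is meant among the compounds shown, and "the series" means these compounds.

Compound 3 (`FC(F)(F)c1ccc2[nH]c(-c3cn(-c4ccccc4)nc3-c3ccc(Cl)cc3)nc2c1`) gives 4420 nM in a functional assay on HeLa cells (Homo sapiens) for antiproliferative activity, read by MTT assay, with a stated time of 48 h (a lower number here means a stronger inhibitor, a higher number a weaker inhibitor), and so stands within the usual scatter of compound 1 (`Cc1ccc2[nH]c(-c3cn(-c4ccccc4)nc3-c3ccc(F)cc3)nc2c1`) at 3630 nM and compound 2 (`Fc1ccc2[nH]c(-c3cn(-c4ccccc4)nc3-c3ccc(Cl)cc3)nc2c1`) at 2770 nM alike. Compound 4 (`Cc1ccc2[nH]c(-c3cn(-c4ccccc4)nc3-c3ccc(Cl)cc3)nc2c1`) carries methyl in place of trifluoromethyl on an aromatic carbon of the shared core. Within the data shown here, the only measured step on that carbon is a 1.6-fold higher number from compound 2 to compound 3 (0.20 log units; within the scatter) and it replaced fluoro with trifluoromethyl without leaving the scatter. Compound 1 also bears methyl there, though it differs elsewhere, and its 3630 nM offers no sign of a larger shift. In this assay no change beyond the scatter is therefore expected, with an estimated 1.3-fold lower number from compound 3 to compound 4 (0.10 log units; within the scatter) only. Compound 4 is estimated at 3500 nM with a range from 1900 nM to 6400 nM expected.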

Compound 4, half-maximal inhibitory concentration: 5360 nM
Compound 4: middle estimate off by 1.5-fold (0.19 log units), on the low side, and the stated range covers the measured number.
By their numbers in this assay, from the lowest: compounds 2, 1, 3 and 4 (each within the scatter of the next).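

With this assay as the read-out, methyl now joins fluoro and trifluoromethyl on this aromatic carbon with no separation among the three: both the swap for trifluoromethyl (a 1.2-fold higher number from compound 3 to compound 4 (0.08 log units; within the scatter)) and the swap for fluoro (a 1.9-fold higher number from compound 2 to compound 4 (0.29 log units; within the scatter)) stay within the scatter. Chloro in place of fluoro on an aromatic carbon elsewhere in the molecule (a 1.5-fold higher number from compound 1 to compound 4 (0.17 log units; within the scatter)) also stays within the scatter. Nothing measured here accounts for these small steps. Going by these compounds, whether an amine or a carboxylic acid on this carbon would move the number beyond the scatter remains open.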